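The source may report more compounds than this note shows. Statements on the series, on what has been measured and on what is new or still open speak of the compounds shown alone.

Measured compounds:
compound 1, `CCOC(=O)Nc1ccc([Se]C#N)cc1`, gives 9800 nM
compound 2, `N#C[Se]c1ccc(NC(=O)Oc2ccccc2)cc1`, gives 22900 nM
compound 3, `CC(C)COC(=O)Nc1ccc([Se]C#N)cc1`, gives 9300 nM

All three were read in a functional assay on CCRF-CEM cells (Homo sapiens) for cytotoxicity, read by MTT assay, with a stated time of 72 h; a higher number here means a weaker inhibitor of growth, a lower number a stronger inhibitor of growth. Compound 3 gives the lowest of the three numbers, but compound 1 lies within the scatter of it, so the two cannot be ordered; only compound 2 stands apart, as a 2.5-fold lower number from compound 2 to compound 3 (0.39 log units; beyond the scatter) shows. The other step beyond the scatter, a 2.3-fold higher number from compound 1 to compound 2 (0.37 log units; beyond the scatter), also turns on the phenyl group on the oxygen next to the carbonyl group. Compound 4, `CCCCOC(=O)Nc1ccc([Se]C#N)cc1`, differs from compound 3 in one place: propyl in place of isopropyl on a saturated chain carbon bound to an oxygen next to a carbonyl group. The step that bears most directly on this is a 1.1-fold lower number from compound 1 to compound 3 (0.02 log units; within the scatter), a change among saturated chains at the same place, which stayed within the scatter. The two steps beyond the scatter both involve the phenyl group and do not speak to a chain rearrangement. Compound 4 is therefore expected to show no step beyond the scatter, a 1.0-fold higher number from compound 3 to compound 4 (0.01 log units; within the scatter). The value of compound 4 is estimated at 9500 nM, in a range from 4800 nM to 19000 nM.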

Compound 4, concentration for 50% growth inhibition: 6500 nM
Compound 4: the middle estimate sits 1.5-fold (0.16 log units) above what was measured; the measured number falls inside the stated range.
By their numbers in this assay, from the lowest: compounds 4, 3 and 1 (each within the scatter of the next); then compound 2.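

Exchanging isobutyl for butyl on the oxygen next to the carbonyl group gives no separable difference (a 1.4-fold lower number from compound 3 to compound 4 (0.16 log units; within the scatter)), and the ethyl chain of compound 1 also cannot be separated from butyl (a 1.5-fold lower number from compound 1 to compound 4 (0.18 log units; within the scatter)), so no difference among the saturated chains from ethyl to butyl is resolved in this assay. Butyl does stand apart from the phenyl group of compound 2 (a 3.5-fold lower number from compound 2 to compound 4 (0.55 log units; beyond the scatter)), the largest step among these compounds, which leaves the split between compound 2 and the three saturated chains as the only one beyond the scatter. Nothing available gives a cause for these numbers.

Going by these compounds, whether a chain longer than butyl, a benzyl group or a chain ending in an amine or a carboxylic acid on this oxygen would move the number beyond the scatter remains open. Also open, on these data alone, is whether a phenyl ring carrying a methoxy group or a chlorine atom would read like compound 2 or like the saturated chains.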